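Pyrazole-acid series: aryl swap at the five-membered ring

The compounds below may be only part of what the source reports. "The series", "measured", "known", "first", "only" and "open" are said of these compounds alone.

Measured so far:
compound 1, `Cc1nn(-c2nc(-c3ccc(Cl)c(Cl)c3)c(SC(C)C)s2)c(C(=O)O)c1-c1ccc(Cl)cc1` — 2500 nM
compound 2, `CCSc1sc(-n2nc(C)c(Cc3ccccc3[N+](=O)[O-])c2C(=O)OC)nc1-c1ccc(Cl)c(Cl)c1` — 106000 nM

In a functional assay on BJAB cells (Homo sapiens) for antiproliferative activity, with a stated time of 4 days (on this read-out higher numbers stand for an effect only at larger amounts of compound and lower numbers for an effect already at smaller amounts), compound 1 gives 2500 nM, the lower of the two numbers. Compound 2 gives 106000 nM, a much higher number, and the gap between the two lies beyond the scatter. Compound 1 and compound 2 differ in several places at once, so nothing can be said of any single change between them; the two values only show that compound 1 acts at smaller amounts.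

Compound 3, `Cc1nn(-c2nc(-c3ccc(Cl)c(Cl)c3)c(SC(C)C)s2)c(C(=O)O)c1-c1ccccc1C(F)(F)F`, is yet to be measured in this assay. The change from compound 1 is 2-(trifluoromethyl)phenyl in place of 4-chlorophenyl on an aromatic carbon. Going by the values given here, no step between measured compounds touches this position, so the expected size of the step rests on nothing more than the general observation that one aromatic ring of carbon only is exchanged for another. The step is expected to be small, most likely no larger than the scatter, with a slight lean toward a higher number; the expected step is a 1.6-fold higher number from compound 1 to compound 3 (0.20 log units; within the scatter). For compound 3 the estimated value in this assay is 4000 nM, within a range of 1200 nM to 15000 nM.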

Compound 3, half-maximal effective concentration: 5200 nM
Beside the measured number, compound 3's estimate is 1.3-fold (0.11 log units) below it; low and high end bracket the measured number.
By their numbers in this assay, from the lowest: compound 1; then compound 3; then compound 2.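

In this assay, going by these compounds alone, this is the first step read at this aromatic carbon of the five-membered ring: a 2.1-fold higher number from compound 1 to compound 3 (0.32 log units; beyond the scatter), a modest change. Thus, with the rest of the core of compound 1 held fixed, 2-(trifluoromethyl)phenyl in place of 4-chlorophenyl leaves the antiproliferative read-out within the same order of magnitude, though the difference is beyond the scatter, and a larger group of 10 heavy atoms in place of 7 still gives a measurable effect. No independent measurement bears on why the number moves, and this single step offers no explanation for it.

The change alters both the substituent and its place on the phenyl ring, so compound 1 and compound 3 leave open whether the step follows from trifluoromethyl in place of chlorine, from the new place on the ring, or from both together. Also open, on these data alone, is how this position would respond to an unsubstituted phenyl, a methoxyphenyl or an aminophenyl, and whether any group here could bring the number below that of compound 1.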